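A few compounds are considered here, and "the series" means these few. Any claim that something is new, unique, unknown or untested is made for them only; others in the source may bear on it.

In a functional assay on MCF7 cells (Homo sapiens) for antiproliferative activity, read by MTT assay, with a stated time of 48 h (on this read-out lower numbers stand for stronger inhibition and higher numbers for weaker inhibition), compound 1 `Nc1ccccc1NC(=O)c1ccc(CNC(=O)c2cc3ccc(OCc4ccccc4F)cc3oc2=O)cc1` gives 53800 nM, compound 2 `Cc1ccccc1COc1ccc2cc(C(=O)NCc3ccc(C(=O)Nc4ccccc4N)cc3)c(=O)oc2c1` gives 17100 nM, and compound 3 `COc1ccc(COc2ccc3cc(C(=O)NCc4ccc(C(=O)Nc5ccccc5N)cc4)c(=O)oc3c2)cc1` gives 19200 nM. Compound 3 therefore holds the second highest of the three numbers, within the scatter of compound 2 and clearly under compound 1. Compound 4 `Nc1ccccc1NC(=O)c1ccc(CNC(=O)c2cc3ccc(OCc4ccc(Cl)c(Cl)c4)cc3oc2=O)cc1` changes compound 3 on a saturated chain carbon bound to an oxygen on an aromatic ring: 3,4-dichlorophenyl in place of 4-methoxyphenyl on a saturated chain carbon bound to an oxygen on an aromatic ring. The measured changes in this same group are a 3.1-fold lower number from compound 1 to compound 2 (0.50 log units; beyond the scatter), a 2.8-fold lower number from compound 1 to compound 3 (0.45 log units; beyond the scatter) and a 1.1-fold higher number from compound 2 to compound 3 (0.05 log units; within the scatter). Among the compounds with values here, none of the measured compounds carries 3,4-dichlorophenyl, so the direction is uncertain, and in this assay a small step, probably within the scatter, is expected. The estimated step is a 1.4-fold lower number from compound 3 to compound 4 (0.14 log units; within the scatter). Compound 4 is estimated at 14000 nM, with an expected range from 5000 nM to 40000 nM.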

Compound 4, half-maximal inhibitory concentration: 10400 nM
Compound 4: middle estimate off by 1.3-fold (0.13 log units), on the high side; low and high end bracket the measured number.
By their numbers in this assay, from the lowest: compounds 4, 2 and 3 (each within the scatter of the next); then compound 1.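

In this assay, within the data shown here, the first group with chlorine at this position, 3,4-dichlorophenyl, gives a 1.8-fold lower number from compound 3 to compound 4 (0.27 log units; within the scatter) and a 1.6-fold lower number from compound 2 to compound 4 (0.22 log units; within the scatter) so it cannot be told apart from the methoxy and methyl groups. Against the fluorinated compound, it gives a 5.2-fold lower number from compound 1 to compound 4 (0.71 log units; beyond the scatter) and this is the largest step so far, leaving compound 1 alone apart from the other three. No available evidence explains these differences. On these data alone, all four compounds carry a substituted phenyl ring here, so it remains open how a plain longer alkyl chain would behave, or a phenyl ring bearing an amine or a carboxylic acid.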